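The source may hold more compounds than are shown below. What is called first, only, known or untested is meant among the compounds shown, and "the series" means these compounds.

Four close relatives sharing one core are compared here. Compound 1 `Brc1ccc(OCCOc2nc3ccccc3s2)cc1` and compound 2 `Clc1ccc(OCCOc2nc3ccccc3s2)cc1` differ only in chloro in place of bromo on an aromatic carbon. In a functional assay on the whole organism with Mus musculus as the target, with a stated time of 1 h, at a dose of 100 mg/kg by the intraperitoneal route (on this read-out lower numbers stand for less inhibition and higher numbers for more inhibition at the one dose given (going by the name of the read-out)), compound 1 gives 94.6%, while compound 2 gives 66.3%, so that a number 28.3 percentage points lower from compound 1 to compound 2 (beyond the scatter). Compound 3 `Brc1ccc(COc2nc3ccccc3s2)cc1` carries a different core; the difference between the two cores is not broken down here. In this assay compound 3 gives 78%. Compound 4 `Clc1ccc(COc2nc3ccccc3s2)cc1` has not yet been measured; it differs from compound 3 in chloro in place of bromo on an aromatic carbon, the same change as that between the first two compounds. Among the compounds with values here, compound 4 is expected to show a number 26 percentage points lower from compound 3 to compound 4 (beyond the scatter) because the same change gave a number 28.3 percentage points lower from compound 1 to compound 2 (beyond the scatter), the only example of it at hand. For compound 4 the estimated result is 52%, expected to fall between 30% and 72%.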

Compound 4, a percentage reported as inhibition, in the whole organism at one dose (the size of the read-out at that dose, not a potency): 82.9%
Compound 4: the middle estimate sits 30.9 percentage points below what was measured; measured number outside the range, above it.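

In this assay, putting chloro in place of bromo on the core of compound 3 gives a number 4.9 percentage points higher from compound 3 to compound 4 (within the scatter), so these two compounds cannot be told apart. The same swap does not give the same result on the two cores: the same change on two cores in this assay, a number 28.3 percentage points lower (beyond the scatter) from compound 1 to compound 2 and a number 4.9 percentage points higher (within the scatter) from compound 3 to compound 4, 33.2 percentage points apart, beyond the scatter of two such steps. Within the data shown here, this shows that a step seen on one core is not a safe guide to the other, but with only one pair on each core it does not show which feature of the cores makes the difference, or how the swap would turn out on a further core.

The compounds shown carry only bromo or chloro on that aromatic carbon. As far as these compounds go, how a fluoro group, a methoxy group or an amine there would read on either core stays open.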